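Diaryl ether in place of the carboxyphenyl arm

This account rests on a few compounds, and the source may have more. Where it says the series, first, only, none or still open, it means among the compounds named here.

Compound 1 `COC(=O)c1cccc(-c2ccc([C@H]3S[C@@H](C)C(=O)Nc4c3c(C)nn4-c3ccccc3C)cc2)c1` — "not active" (no number reported)
Compound 2 `COc1ccccc1-c1ccc([C@H]2S[C@@H](C)C(=O)Nc3c2c(C)nn3-c2ccccc2C)cc1` — 1100 nM
Compound 3 `Cc1ccccc1-n1nc(C)c2c1NC(=O)[C@H](C)S[C@@H]2c1ccc(-c2ccc(C(=O)O)cc2)cc1` — "not active" (no number reported)

In an assay on isolated protein for agonist activity at Bile acid receptor (Homo sapiens), read by AlphaScreen, with a stated time of 30 min (on this read-out lower numbers stand for an effect already at smaller amounts and higher numbers for an effect only at larger amounts of compound), compound 3 gives "not active" (no number reported), so no single number is available for it; compound 1 shares this outcome, and only compound 2, at 1100 nM in this assay, yields a measured concentration. Compound 4 `COc1cccc(Oc2ccc([C@H]3S[C@@H](C)C(=O)Nc4c3c(C)nn4-c3ccccc3C)cc2)c1` has not yet been tested. It differs from compound 3 by a single replacement: 3-methoxyphenoxy in place of 4-carboxyphenyl on an aromatic carbon. Among the compounds with values here, no measured pair separated by exactly one change is available, so the size of this step in this assay cannot be read from a neighbour; the account therefore rests on compound 2, the only member of the set with a number, whose aromatic arm also carries a methoxy group. On that basis compound 4 is expected to show a measurable, if weak, effect in this assay, estimated at 3000 nM with a range from 800 nM to 12000 nM, with a real chance that only a limit is reported.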

Compound 4, half-maximal effective concentration: 1700 nM
Compound 4: the middle estimate sits 1.8-fold (0.25 log units) above what was measured; low and high end bracket the measured number.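

In this assay the step of a 1.5-fold higher number from compound 2 to compound 4 (0.19 log units; within the scatter) shows that this aromatic carbon, para to a large group, carries a 3-methoxyphenoxy arm and a 2-methoxyphenyl arm with no difference that can be told apart. Both arms give a measured concentration, which the 4-carboxyphenyl arm does not, as compound 3 gives "not active" (no number reported). Yet the absence of the free acid is not enough for a number, since compound 1, whose arm carries a methyl ester, gives "not active" (no number reported).

The step alters the link to the ring and the place of the methoxy group together, so the compounds shown leave open what each contributes alone, and how an amine or a hydroxyl group on the phenoxy ring would read. No measurement at hand gives a reason for any of these outcomes.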